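This account rests on a few compounds, and the source may have more. Where it says the series, first, only, none or still open, it means among the compounds named here.

Working notes on the pyrrole acid series. In an assay on cells for inhibition of Palmitoleoyl-protein carboxylesterase NOTUM variant C330S (Homo sapiens), read by fluorescence, with a stated time of 40 min (on this read-out higher numbers stand for weaker inhibition and lower numbers for stronger inhibition), compound 1 `Cc1[nH]c(C(F)(F)F)cc1C(=O)O` gives 6700 nM, compound 2 `Cc1c[nH]cc1C(=O)O` gives 100000 nM and compound 3 `Cc1cc(C(=O)O)c[nH]1` gives 100000 nM. Compound 3 therefore stands level with compound 2, the two together at the top of the three numbers, while compound 1 sits a good deal lower than compound 3, a gap well beyond the scatter. Compound 4 `O=C(O)c1c[nH]c(C(F)(F)F)c1` is compound 3 with one change: trifluoromethyl in place of methyl on an aromatic carbon. Within the data shown here, no measured pair in this assay isolates that change, so its size is only a guess; the lower value of compound 1, which also carries a trifluoromethyl, makes a drop seem more likely than a rise. For compound 4 the step of a 6.7-fold lower number from compound 3 to compound 4 (0.82 log units; beyond the scatter) is expected, giving an estimate of 15000 nM within 4000 nM to 60000 nM in this assay, pending the measurement.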

Compound 4, half-maximal inhibitory concentration: > 100000 nM
Compound 4: only a limit was reported; the forecaster's own chance of this, stated with the estimate: 25%; at least 6.6-fold (0.82 log units) between middle value and limit.
By their numbers in this assay, from the lowest: compound 1; then compounds 2 and 3 (each within the scatter of the next).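

In this assay compound 4 gives > 100000 nM, which is a limit and not a number. Trifluoromethyl in place of methyl next to the ring nitrogen gives a number no lower from compound 3 to compound 4 (the limit leaves the size open), and the size of that step cannot be read because the reading is a limit: the limit of > 100000 nM in this assay, at which 1 of the 4 values shown sits.
Hydrogen in place of methyl on an aromatic carbon gives an at least 14-fold higher number from compound 1 to compound 4 (1.17 log units; beyond the scatter), so trifluoromethyl alone does not bring the lower number of compound 1.

On these data alone, whether an ethyl in place of that methyl, or a nitrile in place of trifluoromethyl, would keep or lower the number of compound 1 stays open.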